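From 3-chlorophenyl to 2-methylphenyl on a carbonyl carbon

The compounds below may be only part of what the source reports. "The series", "measured", "known", "first", "only" and "open" are said of these compounds alone.

In a functional assay on B16-F10 cells (Mus musculus) for antiproliferative activity, read by MTT assay, with a stated time of 48 h (a lower number here means a stronger inhibitor, a higher number a weaker inhibitor), compound 1 (`COc1ccc(/C=C/c2cc(OC)cc(OC)c2/C=C/C(=O)c2cccc(OC)c2)cc1`) gives 4.3 ug/mL and compound 2 (`COc1ccc(/C=C/c2cc(OC)cc(OC)c2/C=C/C(=O)c2ccc(C)cc2)cc1`) gives 5.3 ug/mL while compound 3 (`COc1ccc(/C=C/c2cc(OC)cc(OC)c2/C=C/C(=O)c2cccc(Cl)c2)cc1`) gives 3.3 ug/mL on the same shared core. Compound 3 does not stand apart from the other two. Its measured steps are a 1.3-fold lower number from compound 1 to compound 3 (0.11 log units; within the scatter) and a 1.6-fold lower number from compound 2 to compound 3 (0.21 log units; within the scatter) and the remaining pair shows a 1.2-fold higher number from compound 1 to compound 2 (0.09 log units; within the scatter) so all three numbers sit together.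

Compound 4 (`COc1ccc(/C=C/c2cc(OC)cc(OC)c2/C=C/C(=O)c2ccccc2C)cc1`) differs from compound 3 in one place, 2-methylphenyl in place of 3-chlorophenyl on a carbonyl carbon that is, 2-methylphenyl in place of 3-chlorophenyl on a carbonyl carbon. For the measured compounds named here, no measured compound carries the 2-methylphenyl group, so this exact group is untested. The nearest guide is compound 2, which holds a methyl group on its phenyl ring as 4-methylphenyl, and its step of a 1.6-fold lower number from compound 2 to compound 3 (0.21 log units; within the scatter) is the one that bears most directly, read here in reverse. A move of about that size, back toward a higher number, is therefore what is expected, and nothing beyond the scatter. The expected step is a 1.5-fold higher number from compound 3 to compound 4 (0.16 log units; within the scatter) in this assay on this reasoning. For compound 4 the estimated value is 4.8 ug/mL with an expected range from 2.6 ug/mL to 9 ug/mL in this assay.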

Compound 4, half-maximal inhibitory concentration: 6.1 ug/mL
Estimate against measurement, compound 4: 1.3-fold (0.10 log units) below; the measured number falls inside the stated range.
By their numbers in this assay, from the lowest: compounds 3, 1, 2 and 4 (each within the scatter of the next).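

In this assay the 2-methylphenyl group on the carbonyl carbon joins the other three aryl groups without separating from any of them, as shown by a 1.8-fold higher number from compound 3 to compound 4 (0.27 log units; within the scatter) and by a 1.2-fold higher number from compound 2 to compound 4 (0.06 log units; within the scatter) and also by a 1.4-fold higher number from compound 1 to compound 4 (0.15 log units; within the scatter) on the same shared core. For the compounds shown here, the first of these steps is the largest printed and still lies within the scatter, while the second shows that exchanging 4-methylphenyl for 2-methylphenyl, the first comparison of two methyl-bearing rings at this position, does not register in this read-out, so across the four compounds this position tolerates each of these aryl groups with no measurable preference. Nothing available accounts for these numbers or shows what the groups do at this position.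

Going by these compounds, all four compounds carry a phenyl ring with a single methyl, methoxy or chloro group on the carbonyl carbon, so it remains open whether an amine or a carboxylic acid on that ring, or a longer chain in place of the ring, would move the number beyond the scatter. The compounds shown also leave open whether the shared core's other parts, which never vary here, matter more than this position does.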